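Removing the isopropyl from a piperidine nitrogen

The source may hold more compounds than are shown below. What is called first, only, known or untested is meant among the compounds shown, and "the series" means these compounds.

Measured so far in an assay on HeLa cells for displacement of a labelled ligand from 5-hydroxytryptamine receptor 6 (Homo sapiens); on this read-out higher numbers stand for weaker inhibition and lower numbers for stronger inhibition:
compound 1 `O=S(=O)(c1cn(C2CCNC2)c2ncccc12)c1cccc2cccnc12` gives 5.7 nM;
compound 2 `CC(C)N1CCCC(n2cc(S(=O)(=O)C3=C(Cl)NC4SC=CN34)c3cccnc32)C1` gives 1.7 nM;
compound 3 `CC(C)N1CCCC(n2cc(S(=O)(=O)c3cccc(F)c3)c3cccnc32)C1` gives 3.4 nM.

Compound 2 has the lowest number of the three. Its nearest neighbour is compound 3, reached by a 2.0-fold higher number from compound 2 to compound 3 (0.30 log units; within the scatter), a step that stays within the scatter. Its furthest neighbour is compound 1, which lies beyond the scatter from compound 2; compound 1 differs from compound 2 in more than one place, so its two values can only be set side by side, not read as a single step.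

Compound 4 `O=S(=O)(C1=C(Cl)NC2SC=CN12)c1cn(C2CCCNC2)c2ncccc12` is not yet measured. It differs from compound 2 by hydrogen in place of isopropyl on an amine nitrogen in a ring. Within the data shown here, no measured step touches this amine nitrogen: the one step known changes the group on the sulfonyl sulfur and is within the scatter. For compound 4 a step of a 1.8-fold higher number from compound 2 to compound 4 (0.25 log units; within the scatter) is therefore expected, small and not clearly beyond the scatter. Compound 4 is estimated at 3 nM, in a range from 1.2 nM to 8 nM.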

Compound 4, inhibition constant: 0.7 nM
Compound 4: middle estimate off by 4.3-fold (0.63 log units), on the high side; the measured number lies below the stated range.
By their numbers in this assay, from the lowest: compound 4; then compounds 2, 3 and 1 (each within the scatter of the next, the first and the last beyond it).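

In this assay, among these compounds, the amine nitrogen in the six-membered ring is the first place where a single change moves the number beyond the scatter: going from 1-isopropylpiperidin-3-yl to piperidin-3-yl gives a 2.4-fold lower number from compound 2 to compound 4 (0.39 log units; beyond the scatter) and is a modest step, whereas the only earlier step, on the sulfonyl sulfur, stayed within the scatter. This one pair shows that the isopropyl is not required for a low number here, and that the free amine hydrogen gives the lower number of the two. Nothing at hand bears on why the number falls.

On these data alone, whether the same change holds with the fluorophenyl sulfonyl group of compound 3 stays open. So does what a methyl, an ethyl or an acetyl on this nitrogen would give, as only hydrogen and isopropyl are compared here.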